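This account rests on a few compounds, and the source may have more. Where it says the series, first, only, none or still open, it means among the compounds named here.

Working notes on the series. Going by the values given here, in a functional assay on HCT-116 cells (Homo sapiens) for cytotoxicity, read by MTT assay, with a stated time of 72 h (on this read-out lower numbers stand for stronger inhibition and higher numbers for weaker inhibition), compound 1 `N[C@H]1CC[C@H](Nc2c(C(=O)NCc3ccc(F)cc3)nc(N3CCCCC3)c3cccnc23)CC1` gives 8000 nM, the only actual number among the measured compounds. Compound 2 `O=C(NCc1ccc(F)cc1)c1nc(Br)c2cccnc2c1NCCO` reads > 20000 nM, which is a limit. Compound 3 `C[C@H](NC(=O)c1nc(Br)c2cccnc2c1N[C@H]1CC[C@H](N)CC1)c1ccc(F)cc1` reads > 10000 nM, which is also a limit. Compound 2 therefore has no number of its own, and its place in the series is known only through that limit.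

The next compound to read is compound 4 `O=C(NCc1ccc(F)cc1)c1nc(Br)c2cccnc2c1NCc1ccccc1`, which has not yet been measured. It carries phenyl in place of hydroxymethyl on a saturated chain carbon bound to a nitrogen on an aromatic ring, so that 2-hydroxyethyl becomes benzyl: phenyl in place of hydroxymethyl on a saturated chain carbon bound to a nitrogen on an aromatic ring.

Among the compounds with values here, no measured pair differs in one place only, so the data give no direct size for such a change. Within the data shown here, the expectation rests loosely on compound 1 at 8000 nM, the one measured compound with an actual number. The expected move, an at least 1.3-fold lower number from compound 2 to compound 4 (0.12 log units; that floor lies within the scatter), is small and towards stronger inhibition, and it may not exceed the scatter. A second limit reading would be no surprise. In this assay the estimate for compound 4 is 15000 nM, with the result expected between 5000 nM and 35000 nM.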

Compound 4, half-maximal inhibitory concentration: > 20000 nM
Compound 4 was reported as a limit; the forecaster's own chance of this, stated with the estimate: 50%; at least 1.3-fold (0.12 log units) between middle value and limit.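

Compound 2 and compound 4 both stand as limits in this assay, so no step can be read between them and the change from 2-hydroxyethyl to benzyl has no size here. The compounds shown leave open how far either compound lies beyond its limit, and whether that change moves the read-out at all.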